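Benzylamine variation on a diaminoquinoxaline growth-inhibition series

A few compounds are considered here, and "the series" means these few. Any claim that something is new, unique, unknown or untested is made for them only; others in the source may bear on it.

Measured so far:
compound 1 `Nc1cc(N)c2nc(-c3ccccc3)c(NCc3ccc(Cl)c(Cl)c3)nc2c1` gives 1740 nM
compound 2 `Nc1cc(N)c2nc(-c3ccccc3)c(Oc3ccc(F)cc3)nc2c1` gives 8320 nM
compound 3 `COc1cc(CNc2nc3cc(N)cc(N)c3nc2-c2ccccc2)cc(OC)c1OC` gives 2190 nM

All three numbers come from a functional assay on PC-3 cells (Homo sapiens) for inhibition, read by sulforhodamine B assay, with a stated time of 48 h; on this read-out higher numbers stand for weaker inhibition of growth and lower numbers for stronger inhibition of growth. Compound 1 holds the lowest number of the three. Its nearest neighbour is compound 3, whose number lies within the scatter of that of compound 1, so no order between the two can be read. Compound 2 stands further off, beyond the scatter, and is the weakest inhibitor of growth among the three measured.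

The next compound, compound 4 `Nc1cc(N)c2nc(-c3ccccc3)c(NCc3ccc(F)cc3)nc2c1`, has not yet been run in this assay. It differs from compound 1 in one place: 4-fluorophenyl in place of 3,4-dichlorophenyl on a saturated chain carbon bound to a nitrogen on an aromatic ring. Among the compounds with values here, no measured pair isolates this change, so its size is not known from data here. Because compound 1 gives 1740 nM and compound 3 gives 2190 nM, two different benzyl groups on the same core give numbers within the scatter of each other, which speaks against a large effect of the benzyl substituent pattern. The step from compound 1 to compound 4 is therefore expected to be small, a 1.4-fold higher number from compound 1 to compound 4 (0.16 log units; within the scatter), possibly none beyond the scatter, with a lean toward a somewhat higher number. Compound 4 is estimated at 2500 nM, within the range 900 nM to 7000 nM.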

Compound 4, concentration for 50% growth inhibition: 3470 nM
The estimate for compound 4 lay 1.4-fold (0.14 log units) below the measured number, and the stated range covers the measured number.
By their numbers in this assay, from the lowest: compounds 1, 3 and 4 (each within the scatter of the next); then compound 2.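

In this assay, within the data shown here, 4-fluorophenyl in place of 3,4-dichlorophenyl on a saturated chain carbon bound to a nitrogen on an aromatic ring gives a first direct reading of this position (a 2.0-fold higher number from compound 1 to compound 4 (0.30 log units; within the scatter)), so this exchange of benzyl substituents cannot be told apart from the scatter. The series also gains its first readable change beyond the scatter, though a modest one: (4-fluorobenzyl)amino in place of 4-fluorophenoxy on an aromatic carbon (a 2.4-fold lower number from compound 2 to compound 4 (0.38 log units; beyond the scatter)). No measurement here bears on why either step has its size.

As far as these compounds go, whether the gain from (4-fluorobenzyl)amino over 4-fluorophenoxy carries over to other aryl groups remains open. Also open, from the compounds shown here alone, is whether a longer chain, such as 2-phenylethylamino, or a carboxylic acid on the benzyl group would move the number beyond the scatter.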